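The source may hold more compounds than are shown below. What is called first, only, known or untested is meant among the compounds shown, and "the series" means these compounds.

Three compounds have been measured in a functional assay on HepG2 cells (Homo sapiens) for inhibition, read by MTT assay, with a stated time of 48 h; a higher number here means a weaker inhibitor, a lower number a stronger inhibitor:

compound 1 `Fc1ccccc1CSc1nnc(-c2ccncc2)n1-c1ccccc1`, which gives only a limit of the assay, > 50000 nM;
compound 2 `Brc1cccc(CSc2nnc(-c3ccncc3)n2-c2ccccc2)c1`, which gives 7040 nM;
compound 3 `c1ccc(CSc2nnc(-c3ccncc3)n2-c2ccccc2)cc1`, which gives 12900 nM.

Compound 3 carries a plain phenyl on the saturated chain carbon bound to the sulfur. Its number and that of compound 2 lie within the usual scatter of each other, as a 1.8-fold higher number from compound 2 to compound 3 (0.26 log units; within the scatter) shows, so the two cannot be ordered. Compound 1 stands apart only as a limit, (the limit of > 50000 nM in this assay, at which 1 of the 3 values shown sits).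

Compound 4 `O=[N+]([O-])c1ccc(CSc2nnc(-c3ccncc3)n2-c2ccccc2)cc1` differs from compound 3 by nitro in place of hydrogen on an aromatic carbon. For the measured compounds named here, two measured steps touch the same phenyl: an at least 3.8-fold lower number from compound 1 to compound 3 (0.58 log units; beyond the scatter), which is beyond the scatter, and a 1.8-fold higher number from compound 2 to compound 3 (0.26 log units; within the scatter), which is within it. Neither concerns a nitro group, nor the place para to a large group, so the guidance is thin. A step of no more than modest size is expected for a 1.3-fold lower number from compound 3 to compound 4 (0.11 log units; within the scatter), with no firm direction. Compound 4 is therefore estimated at 10000 nM in this assay, with a range from 3000 nM to 40000 nM.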

Compound 4, half-maximal inhibitory concentration: > 50000 nM
Compound 4 gave a limit, no number (the forecaster's own chance of this, stated with the estimate: 15%); middle value at least 5.0-fold (0.69 log units) from the limit.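

The change from phenyl to 4-nitrophenyl, on an aromatic carbon para to a large group, gives an at least 3.8-fold higher number from compound 3 to compound 4 (0.58 log units; beyond the scatter), so this place on the phenyl does not accept every group without loss in this assay. Measured against the 3-bromophenyl, the change to 4-nitrophenyl gives an at least 7.1-fold higher number from compound 2 to compound 4 (0.85 log units; beyond the scatter), and this step too is beyond the scatter. Compound 4 gives only a limit, and the step between it and compound 1 cannot be read, as both end at the same limit: the limit of > 50000 nM in this assay, at which 2 of the 4 values shown sit.

From the compounds shown here alone, how far the true value of compound 4 lies past that limit remains open. Also open, going by these compounds, is whether an amine or a carboxylic acid on the same aromatic carbon would behave like nitro, and whether nitro would give the same result elsewhere on the phenyl.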